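Propyl in Place of Hydroxy: An Expected Step

This account rests on a few compounds, and the source may have more. Where it says the series, first, only, none or still open, it means among the compounds named here.

Compound 2 `CN(C)C(=O)c1cccnc1NCCCN1CCN(c2ccccc2O)CC1` gives, in a functional assay for antagonist activity at Alpha-1A adrenergic receptor (Oryctolagus cuniculus) (on this read-out higher numbers stand for weaker binding and lower numbers for tighter binding), a value of 5.01 nM. Of the two compounds measured it stands at the higher of the two numbers: compound 1 `COc1ccccc1N1CCN(CCCNc2ncccc2C(=O)C2CC2)CC1` gives 0.501 nM in this assay, a difference the two numbers show to be beyond the scatter. Among the compounds with values here, compound 1 and compound 2 differ in more than one place, so no single step between them is counted.

Compound 3 `CCCc1ccccc1N1CCN(CCCNc2ncccc2C(=O)N(C)C)CC1` is not yet measured in this assay. It differs from compound 2 in one place: propyl in place of hydroxy on an aromatic carbon. Within the data shown here, nothing among the measured compounds isolates this change, and no step is counted for it, so the direction of the step is uncertain. The account therefore expects only a modest step from compound 2 to compound 3, a 1.7-fold lower number from compound 2 to compound 3 (0.22 log units; within the scatter), leaning toward a lower number. Compound 3 is estimated at 3 nM, with a range from 0.8 nM to 12 nM.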

Compound 3, dissociation constant: 0.2 nM
For compound 3 the middle estimate is 15-fold (1.18 log units) above the measured one, and the stated range ends above it.
By their numbers in this assay, from the lowest: compound 3; then compound 1; then compound 2.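

In this assay, the change from 2-hydroxyphenyl to 2-propylphenyl gives a 25-fold lower number from compound 2 to compound 3 (1.40 log units; beyond the scatter), the first step read at this place on an aromatic carbon, ortho to a large group. It shows that this place takes propyl, a larger group by heavy atoms, and that the number falls sharply even though the hydrogen-bond donor and acceptor that hydroxy carries are gone, so neither is needed here for a low number on this core. Nothing at hand bears on what lies behind the size of this step.

From the compounds shown here alone, it remains open whether the step belongs to propyl in particular or would also appear with a shorter chain such as ethyl, a longer chain such as butyl, or an amine at this place. Going by these compounds, it also remains open whether the same change would give a step of similar size on the core of compound 1.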